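Swapping the aryl on compound 2: an untested change

The compounds below may be only part of what the source reports. "The series", "measured", "known", "first", "only" and "open" are said of these compounds alone.

Compound 2 `Cc1cc(=O)n(-c2ccc(Br)cc2F)nc1C(=O)Nc1ccc(Oc2ncnc3c2ccn3C)c(F)c1` gives 14400 nM in a functional assay on A549 cells (Homo sapiens) for cytotoxicity, read by MTT assay, with a stated time of 72 h (on this read-out lower numbers stand for stronger inhibition and higher numbers for weaker inhibition), the higher of the two numbers shown. For the measured compounds named here, compound 1 `Cc1cc(=O)n(-c2ccc(Br)cc2F)nc1C(=O)Nc1ccc(Oc2ncnc3[nH]ccc23)c(F)c1` gives 6120 nM in this assay, and the only measured step, a 2.4-fold higher number from compound 1 to compound 2 (0.37 log units; beyond the scatter), concerns methyl in place of hydrogen on an aromatic nitrogen. Compound 3 `Cc1cc(=O)n(-c2ccccc2Cl)nc1C(=O)Nc1ccc(Oc2ncnc3c2ccn3C)c(F)c1` is not yet measured and differs from compound 2 by 2-chlorophenyl in place of 4-bromo-2-fluorophenyl on an aromatic nitrogen. Going by the values given here, no measured step bears on this change, so the data give no direction for it. The resulting step is expected to stay within the scatter, a 1.0-fold lower number from compound 2 to compound 3 (0.01 log units; within the scatter). Compound 3 is therefore estimated at 14000 nM, with a range from 4500 nM to 45000 nM.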

Compound 3, half-maximal inhibitory concentration: > 60000 nM
Compound 3: a limit, no number; the forecaster's own chance of this, stated with the estimate: 5%; at least 4.2-fold (0.63 log units) between middle value and limit.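

The aryl group on this aromatic nitrogen, held fixed in compound 1 and compound 2, turns out to matter: 2-chlorophenyl in place of 4-bromo-2-fluorophenyl gives an at least 4.1-fold higher number from compound 2 to compound 3 (0.61 log units; beyond the scatter). In this assay compound 3 reads > 60000 nM, which is a limit of the assay and not a number, so the full size of this step stays unknown: the limit of > 60000 nM in this assay, at which 1 of the 3 values shown sits.

The compounds shown cannot separate the part played by the bromine, the fluorine and the chlorine. Also open, on these data alone, is how a methoxy group or an amine on this aryl would read, or 2-chlorophenyl on the core of compound 1.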